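Hydroxymethyl in place of isopropoxycarbonyl in compound 3

This account rests on a few compounds, and the source may have more. Where it says the series, first, only, none or still open, it means among the compounds named here.

Going by the values given here, in a functional assay on the whole organism for inhibition, with Rattus norvegicus as the target, read by paw edema, with stated times of 1 h and 3 h (a higher number here means that more compound is needed for the effect, a lower number that less compound is needed), compound 3 `C/C(=N\OCC(=O)OC(C)C)c1ccc(Cl)cc1` gives 50 mg/kg, the second highest of the three numbers measured so far. Compound 1 `C/C(=N\OCCCCCC(=O)O)c1ccc(Cl)cc1` gives 92 mg/kg, within the scatter of compound 3, so these two are not separated. Compound 2 `CCCOC(=O)CO/N=C(\C)c1ccc(Cl)cc1` gives 14 mg/kg. Among the compounds with values here, the only measured step in one place is a 3.6-fold higher number from compound 2 to compound 3 (0.55 log units; beyond the scatter), a modest step for the change of propyl to isopropyl.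

Compound 4 `C/C(=N\OCCO)c1ccc(Cl)cc1` differs from compound 3 by hydroxymethyl in place of isopropoxycarbonyl on a saturated chain carbon bound to an oxygen. Within the data shown here, no measured step covers this exchange. Among the measured compounds shown here, the one step available alters only the alkyl part of the group that leaves here, so it gives a rough size for changes in this part of the series and no direction. With no direction supported by the data, the expectation stays anchored on compound 3 at 50 mg/kg, and this assay has so far spanned only the values of compound 2 and compound 1. The expected change is a 1.3-fold lower number from compound 3 to compound 4 (0.10 log units; within the scatter), with no step beyond the scatter anticipated, though with low confidence. For compound 4 the estimated value is 40 mg/kg, with an expected range of 15 mg/kg to 110 mg/kg.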

Compound 4, dose for half-maximal effect: 29 mg/kg
Compound 4: middle estimate off by 1.4-fold (0.14 log units), on the high side; the measured number falls inside the stated range.
By their numbers in this assay, from the lowest: compound 2; then compounds 4, 3 and 1 (each within the scatter of the next, the first and the last beyond it).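

In this assay, the isopropoxycarbonyl group is not needed on this saturated chain carbon bound to an oxygen: hydroxymethyl, with 2 heavy atoms against 6 and a hydrogen-bond donor where the leaving group has none, gives a 1.7-fold lower number from compound 3 to compound 4 (0.24 log units; within the scatter) and so does not separate the two compounds. The position therefore tolerates a change that removes the ester altogether, which the propyl-to-isopropyl step could not show. The new alcohol also stands apart from the other two compounds, with a 2.1-fold higher number from compound 2 to compound 4 (0.32 log units; beyond the scatter) for hydroxymethyl in place of propoxycarbonyl, and a 3.2-fold lower number from compound 1 to compound 4 (0.50 log units; beyond the scatter) for hydroxy in place of 3-carboxypropyl, though both of these steps are modest and compound 4 is not separated from compound 3.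

Nothing available bears on what lies behind these steps.

Still open, from the compounds shown here alone, is how an amine or a methoxy group at the end of this short chain would read against the hydroxyl of compound 4, and whether a carboxylic acid on the same short chain would match compound 1 or compound 4. A butoxycarbonyl group would test whether the low number of compound 2 belongs to the straight-chain ester as such.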